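A Bromo-to-Trifluoromethoxy Swap in a Cytotoxicity Series

The source may report more compounds than this note shows. Statements on the series, on what has been measured and on what is new or still open speak of the compounds shown alone.

The compounds measured so far, with their values in a functional assay on NALM-6 cells (Homo sapiens) for cytotoxicity, read by luminescence and CellTiter-Glo, with a stated time of 3 days; a lower number here means a stronger inhibitor, a higher number a weaker inhibitor:

Compound 1, `O=C(Nc1ccc(C(F)(F)F)cc1)c1cc(Cl)c(-c2ccccc2)cc1O`, gives 800 nM.
Compound 2, `O=C(Nc1ccc(Br)c(Cl)c1)c1cc(F)ccc1O`, gives 1250 nM.
Compound 3, `O=C(Nc1cc(C(F)(F)F)cc(C(F)(F)F)c1)c1ccc(Br)cc1O`, gives 1200 nM.

All three share the same amide-linked core and differ only in the groups attached to it. On these numbers compound 2 carries the highest value of the three, yet its gap to compound 3 and its gap to compound 1 both fall within the usual scatter of this assay, so none of the three can be set apart from the others as stronger or weaker.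

Compound 4, `O=C(Nc1ccc(OC(F)(F)F)c(Cl)c1)c1cc(F)ccc1O`, has not yet been measured. It differs from compound 2 in a single place: trifluoromethoxy in place of bromo on an aromatic carbon. Among the compounds with values here, no pair of measured compounds shows what such a swap does in this assay, so the expectation can rest only on the three values already in hand, which sit close together despite their different substituents. The step of a 1.0-fold higher number from compound 2 to compound 4 (0.02 log units; within the scatter) is therefore expected to be small, with no direction that rises beyond the scatter. For compound 4 the estimate is 1300 nM, with a likely range from 500 nM to 3500 nM.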

Compound 4, half-maximal inhibitory concentration: 1000 nM
Estimate against measurement, compound 4: 1.3-fold (0.11 log units) above; the range from low to high includes it.
By their numbers in this assay, from the lowest: compounds 1, 4, 3 and 2 (each within the scatter of the next).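

In this assay, putting trifluoromethoxy in place of bromo on this aromatic carbon, which is ortho to a chloro group and para to a large group, gives a 1.3-fold lower number from compound 2 to compound 4 (0.10 log units; within the scatter). Within the data shown here, this is the first pair that differs in only one place, and it shows that replacing a single bromine with a group of five heavy atoms, one of them counted as a hydrogen-bond acceptor, leaves the number within the scatter at this position. It does not show why the two groups read alike, and no separate measurement here speaks to that question.

From the compounds shown here alone, what remains open is whether any group at this carbon can move the number beyond the scatter, for example an amine, a carboxylic acid or a longer chain such as an ethyl or propyl group, each of which differs in kind from the two groups compared here. A single pair also cannot tell whether the same swap would behave the same way elsewhere on the shared core, or without the neighbouring chloro group.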